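Swapping the amide aryl group at a shared pyrimidine core

A few compounds are considered here, and "the series" means these few. Any claim that something is new, unique, unknown or untested is made for them only; others in the source may bear on it.

Measured compounds:
Compound 1 `CN(C(=O)c1cnc(Cl)nc1C(F)(F)F)c1cc(Cl)cc(Cl)c1` gives 3000 nM in an assay on Jurkat cells for inhibition of cyclic AMP-dependent transcription factor ATF-1 (Homo sapiens); on this read-out higher numbers stand for weaker inhibition and lower numbers for stronger inhibition.
Compound 2 `Cc1ccc(NC(=O)c2cnc(Cl)nc2C(F)(F)F)s1` gives 2800 nM in this assay.

Compound 2 and compound 1 give numbers that lie within the usual scatter of each other, so neither can be called the more active on this evidence. Compound 3 `Cc1cc(NC(=O)c2cnc(Cl)nc2C(F)(F)F)on1` has not yet been measured; it differs from compound 2 by 3-methyl-1,2-oxazol-5-yl in place of 5-methylthiophen-2-yl on an amide-type nitrogen. Among the compounds with values here, no measured pair shows this kind of change, so no step beyond the scatter is expected in either direction. Compound 3 is therefore expected at about 3500 nM, with a range from 1200 nM to 10000 nM, which means an estimated step of a 1.3-fold higher number from compound 2 to compound 3 (0.10 log units; within the scatter).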

Compound 3, half-maximal inhibitory concentration: 3800 nM
Beside the measured number, compound 3's estimate is 1.1-fold (0.04 log units) below it, and the stated range covers the measured number.
By their numbers in this assay, from the lowest: compounds 2, 1 and 3 (each within the scatter of the next).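

Within the data shown here, putting 3-methyl-1,2-oxazol-5-yl in place of 5-methylthiophen-2-yl on the amide-type nitrogen gives the first step that can be read at this position in this assay: a 1.4-fold higher number from compound 2 to compound 3 (0.13 log units; within the scatter). Thus, this exchange of one five-membered aromatic ring for another with one more hetero atom leaves the two numbers within the scatter of each other. Nothing available offers a reason for this result.

The compounds shown leave open whether a cyclohexyl group or a longer alkyl chain on this nitrogen would move the number beyond the scatter.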